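This account rests on a few compounds, and the source may have more. Where it says the series, first, only, none or still open, it means among the compounds named here.

Series notes.

Measured so far:
- compound 1 `Nc1ccccc1-c1ncc(C(=O)O)c(=O)[nH]1`: 50 mg/kg
- compound 2 `CC(C)COc1ccccc1-c1ncc(C(=O)O)c(=O)[nH]1`: 0.5 mg/kg

Both numbers come from a functional assay on the whole organism (strain Sprague-Dawley) for inhibition, with Rattus norvegicus as the target, with a stated time of 10 min; a higher number here means that more compound is needed for the effect, a lower number that less compound is needed. On these two numbers compound 2 stands lowest; compound 1 is the only other point and sits at a far higher dose. Among the compounds with values here, the step of a 100-fold lower number from compound 1 to compound 2 (2.00 log units; beyond the scatter) is the single measured step in the set, and it is large.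

Compound 3 `CCSc1ccccc1-c1ncc(C(=O)O)c(=O)[nH]1` has not yet been measured. Its change from compound 2: ethylsulfanyl in place of isobutoxy on an aromatic carbon. Within the data shown here, the one measured step bears only loosely on this change: it shows that the group at this place on the six-membered aromatic ring of carbon only, ortho to a large group, can move the dose a long way, but it compares amino with isobutoxy, not isobutoxy with ethylsulfanyl. Nothing in the data shows how ethylsulfanyl behaves at this place. The expectation is therefore a modest rise in dose in this assay, a 3.0-fold higher number from compound 2 to compound 3 (0.48 log units; beyond the scatter), much smaller than the measured step and not clearly beyond the scatter. Compound 3 is estimated at 1.5 mg/kg, with a range from 0.4 mg/kg to 6 mg/kg.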

Compound 3, dose for 50% inhibition: 25 mg/kg
For compound 3 the middle estimate is 17-fold (1.22 log units) below the measured one, and the stated range ends below it.
By their numbers in this assay, from the lowest: compound 2; then compounds 3 and 1 (each within the scatter of the next).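

In this assay, the step of a 50-fold higher number from compound 2 to compound 3 (1.70 log units; beyond the scatter) shows that the low dose of compound 2 is tied closely to the isobutoxy group and does not carry over to ethylsulfanyl at this place, ortho to a large group. The step of a 2.0-fold lower number from compound 1 to compound 3 (0.30 log units; within the scatter) puts compound 3 level with compound 1, so among these three compounds the large drop in dose is seen with isobutoxy alone, and replacing amino does not in itself bring it. This change alters both the atom attached to the ring, oxygen to sulfur, and the size of the group, from 5 heavy atoms to 3, and no measurement at hand gives a reason for the size of the step.

The compounds shown leave the two parts of the change unseparated: an ethoxy group would keep the oxygen with the shorter chain, and an isobutylsulfanyl group would keep the sulfur with the longer one. Also open, going by these compounds, is whether a longer alkoxy chain, such as pentyloxy, or a branched one, such as isopropoxy, would hold the dose as low as isobutoxy does in compound 2.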